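A few compounds are considered here, and "the series" means these few. Any claim that something is new, unique, unknown or untested is made for them only; others in the source may bear on it.

Compound 3 `CC(O)CCCC12CCC(c3nnc(-c4ccccc4C(F)(F)F)n3C)(CC1)CC2` is one of three compounds that have been tested in an assay on CHO-K1 cells for inhibition of 11-beta-hydroxysteroid dehydrogenase type 2 (Mus musculus), read by scintillation proximity assay; a lower number here means a stronger inhibitor, a higher number a weaker inhibitor. In this assay compound 3 gives > 4000 nM, which is a limit of the assay and not a number. Compound 1 `CCSCCC12CCC(c3nnc(-c4ccccc4C(F)(F)F)n3C)(CC1)CC2` gives > 4000 nM in this assay, again only a limit. Compound 2 `Cn1c(-c2ccccc2C(F)(F)F)nnc1C12CCC(CNS(C)(=O)=O)(CC1)CC2` gives > 4000 nM in this assay, also a limit. Thus, as the limit of > 4000 nM in this assay, at which 3 of the 3 values shown sit, records, compound 3 stands exactly where its two companions stand, at the limit, and no order among the three can be read. The three measured steps, a step that the two limits leave unreadable from compound 1 to compound 2, a step that the two limits leave unreadable from compound 1 to compound 3 and a step that the two limits leave unreadable from compound 2 to compound 3, cannot be sized; each joins two values that are limits.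

Compound 4 `CC(F)CCCC12CCC(c3nnc(-c4ccccc4C(F)(F)F)n3C)(CC1)CC2` differs from compound 3 by fluoro in place of hydroxy on a saturated chain carbon bound to two saturated chain carbons. Among the measured compounds shown here, none of the measured steps bears directly on this change, and what they do show is that wide variation at the chain end, from a thioether to a sulfonamide to an alcohol, left every compound at the limit. Compound 4 is therefore expected to remain at or beyond that limit, with no readable step in this assay in either direction. Compound 4 is estimated at 8000 nM, within a range of 2500 nM to 40000 nM. The expected step from compound 3 to compound 4 is a step that the limit leaves unreadable from compound 3 to compound 4.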

Compound 4, half-maximal inhibitory concentration: > 4000 nM
Compound 4 was reported as a limit (the forecaster's own chance of this, stated with the estimate: 85%); the middle value lies beyond the limit too.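

In this assay compound 4 gives > 4000 nM and this is a limit, not a number. Its steps to compound 1, compound 2 and compound 3 cannot be read, since all four compounds rest at one limit: the limit of > 4000 nM in this assay, at which 4 of the 4 values shown sit.

The compounds shown leave open how strongly any of the four inhibits, and whether fluoro in place of hydroxy changes anything.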